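Pyrazine replacement on the shared core, compound 3 outlook

A few compounds are considered here, and "the series" means these few. Any claim that something is new, unique, unknown or untested is made for them only; others in the source may bear on it.

Measured compounds:
compound 1 `COc1ccc(OC)c(Sc2ccc3nnc(-c4cnccn4)n3n2)c1`, 880 nM
compound 2 `COc1cncc(-c2nnc3ccc(Sc4cc(OC)ccc4OC)nn23)c1`, 66 nM

For the measured compounds named here, in an assay on isolated protein for inhibition of Leucine-rich repeat serine/threonine-protein kinase 2 (Homo sapiens), in the presence of a further agent that is not named here (a higher number here means a weaker inhibitor, a lower number a stronger inhibitor), compound 1 gives 880 nM, the highest of the two numbers so far; its nearest neighbour is compound 2 at 66 nM. Going by the values given here, the single measured step, a 13-fold lower number from compound 1 to compound 2 (1.12 log units; beyond the scatter), shows that the group attached at this carbon of the shared core moves the read-out by a large amount, well beyond the scatter.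

Compound 3 `COc1ccc(OC)c(Sc2ccc3nnc(-c4ccn(C)n4)n3n2)c1` is not yet measured. It differs from compound 1 as follows: 1-methyl-1H-pyrazol-3-yl in place of pyrazin-2-yl on an aromatic carbon. Among the compounds with values here, no measured pair covers this particular exchange, so the step from compound 1 to compound 2 bears on it only by showing that this position is responsive; it does not show the direction for the new group. The expectation is therefore a modest lowering of the number, with wide uncertainty, estimated as a 2.2-fold lower number from compound 1 to compound 3 (0.34 log units; beyond the scatter). For compound 3 the estimate is 400 nM, with a range from 100 nM to 1500 nM.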

Compound 3, half-maximal inhibitory concentration: 224 nM
For compound 3 the middle estimate is 1.8-fold (0.25 log units) above the measured one, and the stated range covers the measured number.
By their numbers in this assay, from the lowest: compound 2; then compound 3; then compound 1.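

In this assay, a second exchange at this carbon also lowers the number, with a 3.9-fold lower number from compound 1 to compound 3 (0.59 log units; beyond the scatter) for a five-membered aromatic ring in place of the six-membered pyrazin-2-yl; both replacements seen so far therefore give a lower number than pyrazin-2-yl, and this holds although 1-methyl-1H-pyrazol-3-yl has the same counts of heavy atoms, hydrogen-bond donors and hydrogen-bond acceptors as the group it replaces. The groups now also separate from each other, with a 3.4-fold higher number from compound 2 to compound 3 (0.53 log units; beyond the scatter) in favour of 5-methoxypyridin-3-yl, so the response at this position depends on which group enters and not merely on the loss of pyrazin-2-yl. No supporting data are available to account for these differences.

The compounds shown do not separate the effect of each ring from that of its attached group: plain pyridin-3-yl and 1H-pyrazol-3-yl without the methyl would address this for compound 2 and compound 3. From the compounds shown here alone, it also remains open how this carbon of the shared core responds to a ring carrying an amine or a carboxylic acid in place of the methoxy or methyl group.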